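The source may report more compounds than this note shows. Statements on the series, on what has been measured and on what is new or still open speak of the compounds shown alone.

Working notes on the ether chain series. In an ADME assay on RAW264.7 cells (Mus musculus) for cytotoxicity, read by MTT assay, with a stated time of 24 h, in the presence of a further agent that is not named here (on this read-out lower numbers stand for stronger inhibition and higher numbers for weaker inhibition), compound 1 `COc1cc(OC)c2c(c1)C(C(O)c1ccc(O)cc1)OC2=O` gives > 40000 nM as a limit of the assay. Compound 2 `COCCOc1ccc(C(O)C2OC(=O)c3c(OC)cc(OC)cc32)cc1` gives > 40000 nM in this assay as a limit too. Compound 3 `COCCCOc1ccc(C(O)C2OC(=O)c3c(OC)cc(OC)cc32)cc1` stands at > 40000 nM in this assay and this is again only a limit, so no number places it within the series.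

Next is compound 4 `COCCCCOc1ccc(C(O)C2OC(=O)c3c(OC)cc(OC)cc32)cc1`, where the change is methoxymethyl in place of methoxy on a saturated chain carbon, three bonds along the chain from an oxygen on an aromatic ring and reads as methoxymethyl in place of methoxy on a saturated chain carbon, three bonds along the chain from an oxygen on an aromatic ring, taking 3-methoxypropyl to 4-methoxybutyl.

The closest measured precedent is a step that the two limits leave unreadable from compound 2 to compound 3 for the same kind of change one bond nearer the ring. The other two steps are a step that the two limits leave unreadable from compound 1 to compound 2 and a step that the two limits leave unreadable from compound 1 to compound 3 and they give no size either. With no readable step from compound 1, compound 2 or compound 3, the expected size is a step that the limit leaves unreadable from compound 3 to compound 4 in this assay as an estimate, with no direction beyond the scatter.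

For compound 4 the estimate is 55000 nM with an expected range from 30000 nM to 100000 nM in this assay and a further limit is the likely report.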

Compound 4, half-maximal inhibitory concentration: > 40000 nM
Compound 4: a limit, no number; the forecaster's own chance of this, stated with the estimate: 90%; the middle value does not contradict the limit.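

Going by these compounds alone, compound 4 gives only a limit in this assay, so no step from compound 1, compound 2 or compound 3 to compound 4 can be read: the limit of > 40000 nM in this assay, at which 4 of the 4 values shown sit.

The compounds shown leave open whether the length of the ether chain changes this read-out at all.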